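The source may report more compounds than this note shows. Statements on the series, on what has been measured and on what is new or still open speak of the compounds shown alone.

Compound 1 `CCC1(Cc2ccccc2)OS(=O)(=O)C=C1OCc1ccc([N+](=O)[O-])cc1` carries a 4-nitrophenyl group on its shared core. In an ADME assay on HEL cells (Homo sapiens) for cytotoxicity, with a stated time of 3 days (on this read-out lower numbers stand for higher toxicity in this test and higher numbers for lower toxicity in this test), compound 1 gives < 200000 nM, which is a limit of the assay rather than a measured number. Two companions share the same core with other side groups. Compound 2 `CCCC1(Cc2ccccc2)OS(=O)(=O)C=C1OCc1ccccc1` gives 200000 nM in this assay. Compound 3 `CCC1(Cc2ccccc2)OS(=O)(=O)C=C1OCCCCCCc1ccccc1` gives < 200000 nM, again a limit of the assay. Compound 1 therefore stands at the limit of < 200000 nM in this assay, at which 2 of the 3 values shown sit, and with these three values alone no size can be given to any change between them.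

Compound 4 `C=CCOC1=CS(=O)(=O)OC1(CC)Cc1ccccc1` has not yet been measured. It differs from compound 1 in one place: vinyl in place of 4-nitrophenyl on a saturated chain carbon bound to an oxygen on an unsaturated carbon. Going by the values given here, no measured pair shows an exchange of this kind, so no measured step exists to lean on. Since compound 1 sits at the limit of < 200000 nM in this assay, at which 2 of the 3 values shown sit, the change is expected to be a step that the limit leaves unreadable from compound 1 to compound 4, nothing beyond the usual scatter. Compound 4 is estimated at 150000 nM, within a range from 50000 nM to 200000 nM, and the reading may again come back as a limit.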

Compound 4, half-maximal cytotoxic concentration: > 200000 nM
Compound 4 was reported as a limit; the forecaster's own chance of this, stated with the estimate: 60%; middle value at least 1.3-fold (0.12 log units) away from the limit.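

In this assay, the exchange of 4-nitrophenyl for vinyl on a saturated chain carbon bound to an oxygen on an unsaturated carbon gives a number no lower from compound 1 to compound 4 (the limit leaves the size open). Going by these compounds alone, this is the first sign of direction at this place: the number is no lower after the exchange, so lower toxicity in this test is possible, though its size remains unknown. Both readings are limits rather than numbers, and the two limits point in opposite directions, which fixes the direction of the change but not its size: the limit of > 200000 nM in this assay, at which 1 of the 4 values shown sits.

The exchange removes the aromatic ring and the nitro group together, so the compounds shown cannot separate the part played by each. They also leave open whether a different group at this place, such as an amine or a carboxylic acid, would give a measurable number rather than another limit.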